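Swapping the sulfonamide aryl group in a sulfonamide-amide series

The source may hold more compounds than are shown below. What is called first, only, known or untested is meant among the compounds shown, and "the series" means these compounds.

Measured so far:
compound 1, `O=C(Nc1ccc(S(=O)(=O)Nc2ccccc2)cc1)c1ccc(Cl)cc1Br`, 1020 nM
compound 2, `O=C(Nc1ccc(S(=O)(=O)Nc2ccccc2)cc1)c1cc2ccccc2oc1=O`, 7760 nM
compound 3, `O=C(Nc1ccc(S(=O)(=O)Nc2cccc(Cl)c2)cc1)c1ccc(Cl)cc1Cl`, 575 nM

All three share the same core, an amide joined through a benzene ring to a sulfonamide, and were tested in a functional assay on HEK293 cells for agonist activity at probable G-protein coupled receptor 27 (Homo sapiens), read by a luciferase reporter and beta-arrestin recruitment, with a stated time of 10 min; a lower number here means that less compound is needed, a higher number that more compound is needed for the effect. In that assay compound 1 gives 1020 nM, compound 2 gives 7760 nM, and compound 3 gives 575 nM. On the numbers alone compound 3 has the lowest of the three values, but its gap to compound 1 lies within the scatter of the method, so those two cannot be told apart. Compound 2, by contrast, sits beyond the scatter from compound 3.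

Compound 4, `Cc1ccc(NS(=O)(=O)c2ccc(NC(=O)c3ccc(Cl)cc3Cl)cc2)cc1`, has not yet been measured. It differs from compound 3 in one place: 4-methylphenyl in place of 3-chlorophenyl on a sulfonamide nitrogen. For the measured compounds named here, no measured pair shows what this particular change does, since the three compounds so far vary only on the amide side. With no guide from the data, the expectation for compound 4 is a step from compound 3 that stays within the scatter, with no clear direction, which is what a 1.4-fold higher number from compound 3 to compound 4 (0.14 log units; within the scatter) expresses. Compound 4 is therefore estimated at 800 nM, with a range from 250 nM to 2500 nM.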

Compound 4, half-maximal effective concentration: > 100000 nM
Compound 4 was reported as a limit; the forecaster's own chance of this, stated with the estimate: 5%; middle value at least 120-fold (2.09 log units) from the limit.
By their numbers in this assay, from the lowest: compounds 3 and 1 (each within the scatter of the next); then compound 2. At a limit, above all of these: compound 4.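

The earlier compounds vary only on the amide side, so they say nothing about the group on the sulfonamide nitrogen, and compound 3 and compound 4 are the first pair shown that differs there alone. In this assay compound 4 gives a limit and not a number: the limit of > 100000 nM in this assay, at which 1 of the 4 values shown sits. This position turns out to be highly sensitive to the change, with an at least 170-fold higher number from compound 3 to compound 4 (2.24 log units; beyond the scatter), even though 3-chlorophenyl and 4-methylphenyl have the same count of heavy atoms and each is a six-membered aromatic ring of carbon only, with no hydrogen-bond donors or acceptors.

This single pair cannot show whether the step comes with the chlorine leaving, the methyl entering, or the different place of the group on the ring, as all of these change together here. Also open, on these data alone, is how the sulfonamide nitrogen would tolerate other groups, such as a phenyl ring carrying an amine or a carboxylic acid, or a longer chain in place of the ring.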